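From 3-methylphenyl to 2-fluorophenyl: an expected small step

The source may report more compounds than this note shows. Statements on the series, on what has been measured and on what is new or still open speak of the compounds shown alone.

- Compound 1 `COc1cc2c(Oc3ccc(NC(=O)Nc4cccc(C)c4)cc3)ccnc2cc1OCCCCCCC(=O)NO` gives 2010 nM in a functional assay on A549 cells (Homo sapiens) for antiproliferative activity, read by MTT assay; on this read-out lower numbers stand for stronger inhibition and higher numbers for weaker inhibition
- Compound 2 `COc1cc2c(Oc3ccc(NC(=O)Nc4ccc(C(F)(F)F)cc4Cl)cc3)ccnc2cc1OCCCCCCC(=O)NO` gives 970 nM in this assay

Compound 1 holds the higher of the two numbers, so it is the weaker inhibitor of this pair. Compound 3 `COc1cc2c(Oc3ccc(NC(=O)Nc4ccccc4F)cc3)ccnc2cc1OCCCCCCC(=O)NO` has 2-fluorophenyl in place of 3-methylphenyl on an amide-type nitrogen and is otherwise unchanged. Among the measured compounds shown here, only one measured step changes the same place, a 2.1-fold lower number from compound 1 to compound 2 (0.32 log units; beyond the scatter), and it brings in a different group. A small move toward lower numbers in this assay therefore seems likely, perhaps none beyond the scatter. The expected change is a 1.3-fold lower number from compound 1 to compound 3 (0.13 log units; within the scatter) by this estimate. Compound 3 is expected near 1500 nM, with an estimated range from 700 nM to 3200 nM overall.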

Compound 3, half-maximal inhibitory concentration: 870 nM
Estimate against measurement, compound 3: 1.7-fold (0.24 log units) above, within the range that was stated.
By their numbers in this assay, from the lowest: compounds 3 and 2 (each within the scatter of the next); then compound 1.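

In this assay, 2-fluorophenyl on the amide-type nitrogen brings a 2.3-fold lower number from compound 1 to compound 3 (0.36 log units; beyond the scatter) and so becomes the second, quite different group to give a lower number than 3-methylphenyl at this place. Against 2-chloro-4-(trifluoromethyl)phenyl, it shows a 1.1-fold lower number from compound 2 to compound 3 (0.05 log units; within the scatter) and cannot be told apart from that group here. No measurement at hand explains why these groups behave this way.

Still open, going by these compounds, is whether a plain phenyl would sit with 3-methylphenyl or with the two lower compounds. A comparison with 3-fluorophenyl would also be needed to show whether the fluorine's ring position matters.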